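A few compounds are considered here, and "the series" means these few. Any claim that something is new, unique, unknown or untested is made for them only; others in the source may bear on it.

Compound 2 `CCCOCC(=O)Nc1cc2nc(C3CCCCC3)[nH]c2cc1N(CC)CC` was examined in an ADME assay on Vero cells (Chlorocebus sabaeus) for cytotoxicity, read by resazurin assay, with a stated time of 3 days (on this read-out higher numbers stand for weaker inhibition and lower numbers for stronger inhibition), and there compound 2 gives > 100 ug/mL, which is a limit of the assay rather than a number. Compound 1 `CCCNC(=O)Nc1cc2nc(C3CCCCC3)[nH]c2cc1N1CCCC1` was run in the same way; in this assay compound 1 gives > 100 ug/mL, likewise a limit. Both results share (the limit of > 100 ug/mL in this assay, at which 2 of the 2 values shown sit). Compound 3 `CCCNC(=O)Nc1cc2nc(C3CCCCC3)[nH]c2cc1N(CC)CC` has not yet been measured; it differs from compound 2 by propylamino in place of propoxymethyl on a carbonyl carbon. Among the measured compounds shown here, no step between measured compounds is available, so no change beyond the scatter is anticipated in this assay, and the expected step is a number no higher from compound 2 to compound 3 (the limit leaves the size open). Compound 3 is therefore expected to give 100 ug/mL, between 50 ug/mL and 200 ug/mL, most likely again as a limit.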

Compound 3, half-maximal inhibitory concentration: > 100 ug/mL
Compound 3: no number, only a limit; the forecaster's own chance of this, stated with the estimate: 85%; the middle value sits exactly at the limit.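

Compound 3 gives > 100 ug/mL as a limit, so its steps from compound 1 and from compound 2 cannot be read. The compounds shown leave open what size, if any, either change has, as none gives a value inside the measured range.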